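Diaryl urea series: aryl swap from compound 3 to compound 4

A few compounds are considered here, and "the series" means these few. Any claim that something is new, unique, unknown or untested is made for them only; others in the source may bear on it.

Measured compounds in a functional assay on NCI-H460 cells (Homo sapiens) for antiproliferative activity, read by MTT assay, with a stated time of 72 h; a higher number here means a weaker inhibitor, a lower number a stronger inhibitor:
compound 1 `CN(C)CCn1cnnc1-c1cc(Oc2ccc(NC(=O)Nc3ccc(Cl)cc3Cl)cc2F)ccn1`: 4350 nM
compound 2 `CCN(CC)CCn1cnnc1-c1cc(Oc2ccc(NC(=O)Nc3ccc(Cl)c(C(F)(F)F)c3)cc2F)ccn1`: 850 nM
compound 3 `CCN(CC)CCn1cnnc1-c1cc(Oc2ccc(NC(=O)Nc3ccc(F)c(F)c3)cc2F)ccn1`: 14900 nM

Compound 3 gives the highest number of the three, with compound 1 nearest and compound 2 furthest below it. Among the measured compounds shown here, the one measured step that ends at compound 3 is an 18-fold higher number from compound 2 to compound 3 (1.24 log units; beyond the scatter), which shows the urea aryl group has a large bearing on this assay.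

Compound 4 `CCN(CC)CCn1cnnc1-c1cc(Oc2ccc(NC(=O)Nc3ccc(Cl)cc3Cl)cc2F)ccn1` differs from compound 3 in one place: 2,4-dichlorophenyl in place of 3,4-difluorophenyl on an amide-type nitrogen. For the measured compounds named here, no measured step covers this exact swap. Compound 1 carries the same 2,4-dichlorophenyl group on a shorter amine chain and gives 4350 nM, a number well below that of compound 3; compound 2 shows that the diethylamino chain of compound 4 sits with a lower number than compound 1 when paired with a chlorinated aryl group. Both point the same way: the dichlorophenyl group of compound 4 is expected to bring the number down from compound 3, by a step of roughly a 5.0-fold lower number from compound 3 to compound 4 (0.70 log units; beyond the scatter), clearly beyond the scatter though smaller than the step into compound 3. Compound 4 is therefore estimated at 3000 nM, within 1000 nM to 9000 nM.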

Compound 4, half-maximal inhibitory concentration: 5380 nM
For compound 4 the middle estimate is 1.8-fold (0.25 log units) below the measured one, within the range that was stated.
By their numbers in this assay, from the lowest: compound 2; then compounds 1 and 4 (each within the scatter of the next); then compound 3.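

With the diethylamino chain held fixed, the urea aryl position in this assay now resolves into three levels rather than two: a 2.8-fold lower number from compound 3 to compound 4 (0.44 log units; beyond the scatter), and a 6.3-fold higher number from compound 2 to compound 4 (0.80 log units; beyond the scatter). The 2,4-dichlorophenyl group therefore takes a middle level on this chain, with 3,4-difluorophenyl giving the highest number and 4-chloro-3-(trifluoromethyl)phenyl the lowest. The amine end also gets its first comparison with the aryl group held constant, and a 1.2-fold higher number from compound 1 to compound 4 (0.09 log units; within the scatter) shows no readable effect of diethylamino in place of dimethylamino on the 2,4-dichlorophenyl urea, while no available data account for the differences among the aryl groups.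

The compounds shown leave open whether the amine swap stays this silent with 4-chloro-3-(trifluoromethyl)phenyl or 3,4-difluorophenyl on the urea, and whether a cyclic amine such as morpholine or a longer chain would behave the same way. They also do not separate halogen identity from halogen placement, since 2,4-dichlorophenyl and 3,4-difluorophenyl differ in both, and a 3,4-dichlorophenyl group would address that directly.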